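The source may hold more compounds than are shown below. What is called first, only, known or untested is meant among the compounds shown, and "the series" means these compounds.

Measured in an ADME assay on microsomes from liver (Canis lupus familiaris) for metabolic stability, read by LC-MS, using NADPH, with a stated time of 10 min, tested at 0.1 uM; a lower number here means slower removal, a higher number faster removal of the compound:
- compound 1 `CC1SC(c2cccc(C(=O)NCCCCc3ccccc3)c2)N(c2ccc(C3CC3)cc2)C1=O`: 1750 mL.min-1.g-1
- compound 2 `COc1ccc(F)cc1N1C(=O)CSC1c1cccc(C(=O)NCCCCn2cccn2)c1`: 480 mL.min-1.g-1
- compound 3 `COc1ccc(F)cc1N1C(=O)CSC1c1cccc(C(=O)NCCCCc2ccccc2)c1`: 1650 mL.min-1.g-1

Compound 2, at 480 mL.min-1.g-1, has the lowest number of the three. Compound 1 at 1750 mL.min-1.g-1 and compound 3 at 1650 mL.min-1.g-1 both stand well higher, and those two values lie within the scatter of each other.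

Compound 4 `Cc1ccnc(N2C(=O)CSC2c2cccc(C(=O)NCCCCn3cccn3)c2)c1` keeps the 1H-pyrazol-1-yl chain of compound 2 and changes the other end of the molecule: 4-methylpyridin-2-yl in place of 5-fluoro-2-methoxyphenyl on an amide-type nitrogen in a ring.

Among the measured compounds shown here, the only measured single-place step is a 3.4-fold higher number from compound 2 to compound 3 (0.54 log units; beyond the scatter), which is modest and beyond the scatter. It concerns the chain, not the group being exchanged here, so it bears only indirectly. For the measured compounds named here, no measured step isolates a change on the ring nitrogen. Compound 1 and compound 3 differ there and elsewhere, yet their values show no separation. That gives weak support for expecting little movement in this assay, though the data do not test a pyridine at this place.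

The expected step is a 1.1-fold lower number from compound 2 to compound 4 (0.06 log units; within the scatter), a slight lowering estimated to remain within the scatter. For compound 4 the estimated value is 420 mL.min-1.g-1, with an expected range from 180 mL.min-1.g-1 to 950 mL.min-1.g-1.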

Compound 4, intrinsic clearance in microsomes: 41.8 mL.min-1.g-1
Compound 4: middle estimate off by 10-fold (1.00 log units), on the high side, and the stated range ends above it.
By their numbers in this assay, from the lowest: compound 4; then compound 2; then compounds 3 and 1 (each within the scatter of the next).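

In this assay, the group on the amide-type nitrogen in the ring is not a silent place: with the 1H-pyrazol-1-yl chain held fixed, 4-methylpyridin-2-yl in place of 5-fluoro-2-methoxyphenyl gives an 11-fold lower number from compound 2 to compound 4 (1.06 log units; beyond the scatter). Among the compounds shown here, the only earlier single-place step, a 3.4-fold higher number from compound 2 to compound 3 (0.54 log units; beyond the scatter), lay on the chain, so this result adds a second place at which the number moves beyond the scatter, and here the step is large rather than modest. Nothing measured accounts for the drop, and the exchange alters several features at once, namely the methoxy, the fluorine, a ring carbon replaced by nitrogen and the added methyl, so the step cannot be assigned to any one of them.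

From the compounds shown here alone, whether the same exchange lowers the number as far on the phenyl chain of compound 3 remains open, since only the 1H-pyrazol-1-yl chain carries the pyridine here. A plain phenyl or a pyridine ring lacking the methyl at this place would be needed to separate the contribution of the ring nitrogen from those of the substituents.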